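Thiophene carboxamide series: ring-amine substituent change

The source may report more compounds than this note shows. Statements on the series, on what has been measured and on what is new or still open speak of the compounds shown alone.

Measured so far:
compound 1 `NC(=O)c1c(NC(=O)c2ccccc2Cl)sc2c1CCN(Cc1ccccc1Cl)C2` — 27500 nM
compound 2 `NC(=O)c1c(NC(=O)c2ccccc2F)sc2c1CCN(Cc1cccc(Cl)c1)C2` — 49500 nM

In a functional assay on HeLa cells (Homo sapiens) for antiproliferative activity, with a stated time of 24 h (a lower number here means a stronger inhibitor, a higher number a weaker inhibitor), compound 1 gives 27500 nM, and compound 2 gives 49500 nM; the two values lie within the scatter of each other, so neither stands apart. For the measured compounds named here, no step between measured compounds is known, and nothing on the shared core shows how this assay answers to a change on the ring amine.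

Compound 3 `NC(=O)c1c(NC(=O)c2ccccc2Cl)sc2c1CCN(C(=S)Nc1ccccc1)C2` differs from compound 1 by a group of 9 heavy atoms (7 carbon, 1 nitrogen, 1 sulfur; one six-membered aromatic ring of carbon only) in place of a group of 8 heavy atoms (7 carbon, 1 chlorine; one six-membered aromatic ring of carbon only), on an amine nitrogen in a ring, a thiourea in place of a benzyl group. Going by the values given here, with no comparable step to lean on, the change from compound 1 to compound 3 is expected to stay within the scatter, as a 1.1-fold higher number from compound 1 to compound 3 (0.04 log units; within the scatter) shows, with no set direction. Compound 3 is estimated at 30000 nM, in a range from 8000 nM to 100000 nM.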

Compound 3, half-maximal inhibitory concentration: 46700 nM
Beside the measured number, compound 3's estimate is 1.6-fold (0.19 log units) below it, and the stated range covers the measured number.
By their numbers in this assay, from the lowest: compounds 1, 3 and 2 (each within the scatter of the next).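

On an amine nitrogen in a ring, this assay now has its first readable step, a thiourea in place of 2-chlorobenzyl (a 1.7-fold higher number from compound 1 to compound 3 (0.23 log units; within the scatter)). This position therefore accepts an exchange that adds a hydrogen-bond donor and a hydrogen-bond acceptor, and the step stays within the scatter. No outside measurement bears on this result.

Open, as far as these compounds go, is whether a urea, with oxygen in place of the thiourea sulfur, would also stay within the scatter. Also open, from the compounds shown here alone, is whether an aminoethyl chain or a carboxylic acid on this nitrogen would move the number beyond it.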